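A few compounds are considered here, and "the series" means these few. Any claim that something is new, unique, unknown or untested is made for them only; others in the source may bear on it.

Compound 1 `CNc1nc(N)n2nc(-c3ccco3)nc2n1` is a small molecule on a shared core that carries a methylamino group and a free amino group. For the measured compounds named here, in an assay on CHO cells for displacement of a labelled ligand from adenosine receptor A3 (Homo sapiens) (on this read-out lower numbers stand for stronger inhibition and higher numbers for weaker inhibition), compound 1 gives 1560 nM, the highest of the three numbers measured so far. Compound 2 `CC(C)Nc1nc(N)n2nc(-c3ccco3)nc2n1` differs from it in one place, and in this assay compound 2 gives 568 nM. Compound 3 `c1coc(-c2nc3nc(NC4CCCCC4)nc(NC4CCCCC4)n3n2)c1`, which bears a cyclohexyl group on each of its two ring nitrogens, gives 129 nM in this assay, a lower number than that of compound 1.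

Compound 4 `CNc1nc(NCc2ccc(F)cc2)n2nc(-c3ccco3)nc2n1` is the next step from compound 1: 4-fluorobenzyl in place of hydrogen on a nitrogen on an aromatic ring. Going by the values given here, the one measured step that bears on this is a 2.7-fold lower number from compound 1 to compound 2 (0.44 log units; beyond the scatter), where a larger group on a ring nitrogen of this core went with a lower number; the value of compound 3 points the same way. The expected change is a 5.2-fold lower number from compound 1 to compound 4 (0.72 log units; beyond the scatter), a lowering beyond the scatter. For compound 4 in this assay a value of 300 nM is estimated, within a range from 80 nM to 1100 nM.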

Compound 4, inhibition constant: 557 nM
Beside the measured number, compound 4's estimate is 1.9-fold (0.27 log units) below it; low and high end bracket the measured number.
By their numbers in this assay, from the lowest: compound 3; then compounds 4 and 2 (each within the scatter of the next); then compound 1.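

Placing 4-fluorobenzyl on the free amino nitrogen gives a 2.8-fold lower number from compound 1 to compound 4 (0.45 log units; beyond the scatter) in this assay and so keeps the compound measurable with this large group in place. The earlier step, a 2.7-fold lower number from compound 1 to compound 2 (0.44 log units; beyond the scatter), changed the group on the methylamino nitrogen, so this is the first listed step to show that the free amino nitrogen is also open to change. The new group brings in a six-membered aromatic ring of carbon only, yet no measured evidence here explains the lower number.

On these data alone, it remains open whether the lowering goes with the aromatic ring, the fluorine or the added carbon atoms. A plain benzyl group or an ethyl group on this same nitrogen would help to separate these possibilities.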